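The source may hold more compounds than are shown below. What is called first, only, known or untested is meant among the compounds shown, and "the series" means these compounds.

Compounds measured so far in this study:
compound 1, `Cc1ccc(O)c(/C=N\NC(=O)c2oc3cccc(O)c3c2C)c1`, with 7350 nM in a functional assay on PC-3 cells (Homo sapiens) for inhibition; on this read-out lower numbers stand for stronger inhibition and higher numbers for weaker inhibition.
compound 2, `Cc1c(C(=O)N/N=C\c2ccccn2)oc2cccc(O)c12`, for which the read-out is only a limit, >= 40000 nM.

Going by these compounds, of the two values shown, compound 2 sits at the limit of the assay, as the record of the limit of >= 40000 nM in this assay, at which 1 of the 2 values shown sits, states, so its true number is unknown. For the measured compounds named here, the single measured step, an at least 5.4-fold higher number from compound 1 to compound 2 (0.73 log units; beyond the scatter), is the only guide available, and it describes the exchange of a 2-hydroxy-5-methylphenyl for a pyridin-2-yl.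

Compound 3, `Cc1c(C(=O)N/N=C\c2cc(Cl)ccc2O)oc2cccc(O)c12`, has not yet been measured. It differs from compound 2 in one place: 5-chloro-2-hydroxyphenyl in place of pyridin-2-yl on a carbon with a double bond to nitrogen. This change reverses the measured step in kind, since the 5-chloro-2-hydroxyphenyl entering in compound 3 resembles the 2-hydroxy-5-methylphenyl of compound 1 more than it resembles the pyridin-2-yl of compound 2. Compound 3 is therefore expected to return toward the level of compound 1, an expected step of an at least 5.7-fold lower number from compound 2 to compound 3 (0.75 log units; beyond the scatter). The estimate for compound 3 is 7000 nM, with a range from 2000 nM to 30000 nM.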

Compound 3, half-maximal inhibitory concentration: 3120 nM
For compound 3 the middle estimate is 2.2-fold (0.35 log units) above the measured one; the range from low to high includes it.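

In this assay, for the compounds shown here, 5-chloro-2-hydroxyphenyl in place of pyridin-2-yl on a carbon with a double bond to nitrogen gives an at least 12-fold lower number from compound 2 to compound 3 (1.10 log units; beyond the scatter), so the level lost with pyridin-2-yl is regained, and with a hydroxyphenyl group other than the one in compound 1. Going by these compounds, the true size of that step remains unknown, as the read-out for compound 2 is only a limit: the limit of >= 40000 nM in this assay, at which 1 of the 3 values shown sits. The change from compound 1 adds something new, as chloro in place of methyl on an aromatic carbon gives a 2.4-fold lower number from compound 1 to compound 3 (0.37 log units; beyond the scatter), which shows that the read-out responds to this one ring substituent and that a modest gain lies beyond the scatter.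

The step from pyridin-2-yl changes the ring, the hydroxy group and the chloro together, so the compounds shown do not tell which of these carries the difference. On these data alone, it also remains open whether the gain from chloro extends to other groups on that aromatic carbon, such as bromo, methoxy or an amine, or whether the hydroxy group can give way to a methoxy group without a loss.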